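Benzyl swap on a sulfanyl-linked sulfonylguanidine series

The compounds below may be only part of what the source reports. "The series", "measured", "known", "first", "only" and "open" are said of these compounds alone.

Measured compounds:
compound 1, `Cc1cc(S(=O)(=O)/N=C(\N)n2nccc2-c2ccccc2)c(SCc2cccc(Cl)c2)cc1Cl`, 10000 nM
compound 2, `Cc1cc(-c2ccccc2)n(/C(N)=N/S(=O)(=O)c2cc(C)c(Cl)cc2SCc2ccc(C(F)(F)F)cc2)n1`, 18000 nM
compound 3, `Cc1cc(-c2ccccc2)n(/C(N)=N/S(=O)(=O)c2cc(C)c(Cl)cc2SCc2cccc(Cl)c2)n1`, 18000 nM

In an ADME assay on HaCaT cells (Homo sapiens) for cytotoxicity, read by MTT assay, with a stated time of 72 h (on this read-out higher numbers stand for weaker inhibition and lower numbers for stronger inhibition), compound 1 gives the smallest of the three numbers, but the step of a 1.8-fold higher number from compound 1 to compound 3 (0.26 log units; within the scatter) and the gap to compound 2 both lie within the scatter, so the three compounds cannot be told apart on this read-out. The step from compound 2 to compound 3, no change at the digits printed from compound 2 to compound 3 (within the scatter), is the one that bears most directly on compound 4. That step also exchanges the aromatic group on the saturated chain carbon bound to a sulfur.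

Compound 4, `Cc1cc(S(=O)(=O)/N=C(\N)n2nccc2-c2ccccc2)c(SCc2ccccc2C)cc1Cl`, differs from compound 1 by 2-methylphenyl in place of 3-chlorophenyl on a saturated chain carbon bound to a sulfur. Since the comparable exchange between compound 2 and compound 3 produced no change, and the methyl step a 1.8-fold higher number from compound 1 to compound 3 (0.26 log units; within the scatter) stayed within the scatter, no step beyond the scatter is expected for compound 4 in this assay. The expected step is a 1.2-fold higher number from compound 1 to compound 4 (0.08 log units; within the scatter). Compound 4 is therefore estimated at 12000 nM, with a range from 5000 nM to 30000 nM.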

Compound 4, half-maximal inhibitory concentration: 18000 nM
Estimate against measurement, compound 4: 1.5-fold (0.18 log units) below; the range from low to high includes it.
By their numbers in this assay, from the lowest: compounds 1, 2, 3 and 4 (each within the scatter of the next).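

In this assay, 2-methylphenyl in place of 3-chlorophenyl on the saturated chain carbon bound to a sulfur gives a 1.8-fold higher number from compound 1 to compound 4 (0.26 log units; within the scatter). Until now, an exchange at this place had been seen only between compound 2 and compound 3, on the methyl-bearing form of the core; this result adds a second exchange, on the core of compound 1, and it too cannot be read as a change. Here a chlorine leaves and a methyl enters on the aromatic group, yet the read-out does not separate the two compounds. Nothing shown gives a measured reason for this result.

The compounds shown leave open whether an amine or a carboxylic acid on the benzyl group, or a longer chain between the sulfur and the aromatic ring, would give a step beyond the scatter in this assay. As far as these compounds go, how an unsubstituted phenyl would read at this place also remains open.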